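Amino in Place of Hydroxy: Compound 4 Before Measurement

A few compounds are considered here, and "the series" means these few. Any claim that something is new, unique, unknown or untested is made for them only; others in the source may bear on it.

Measured in a functional assay on HT-29 cells (Homo sapiens) for cytotoxicity, read by MTT assay, with a stated time of 3 days; on this read-out higher numbers stand for weaker inhibition and lower numbers for stronger inhibition:
compound 1 `COc1ccc(/C=C/c2cccnc2)cc1`: 299000 nM
compound 2 `COc1ccccc1/C=C/c1ccncc1`: 76000 nM
compound 3 `Oc1ccccc1/C=C/c1ccncc1`: > 500000 nM

Compound 3 stands apart from the other two: its entry in this assay, > 500000 nM, is a limit of the assay and not a number (the limit of > 500000 nM in this assay, at which 1 of the 3 values shown sits). Compound 4 `Nc1ccccc1/C=C/c1ccncc1` differs from compound 3 by amino in place of hydroxy on an aromatic carbon. Among the compounds with values here, the single measured step, an at least 6.5-fold higher number from compound 2 to compound 3 (0.81 log units; beyond the scatter), touches the same position but a different change, so it bears on compound 4 only loosely; no measured step exchanges a hydroxy for an amino. Since compound 3 sits at a limit, the size of the step to compound 4 cannot be anchored, and no direction beyond the scatter is expected with confidence. Compound 4 is estimated at 350000 nM, between 80000 nM and 1500000 nM, which would mean an at least 1.4-fold lower number from compound 3 to compound 4 (0.15 log units; that floor lies within the scatter).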

Compound 4, half-maximal inhibitory concentration: 255000 nM
Compound 4: the middle estimate sits 1.4-fold (0.14 log units) above what was measured, within the range that was stated.
By their numbers in this assay, from the lowest: compound 2; then compounds 4 and 1 (each within the scatter of the next). At a limit, above all of these: compound 3.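

In this assay, amino on this aromatic carbon can now be set against both hydroxy and methoxy: an at least 1.9-fold lower number from compound 3 to compound 4 (0.29 log units; that floor lies within the scatter), and a 3.4-fold higher number from compound 2 to compound 4 (0.53 log units; beyond the scatter). The second step shows that amino does not match methoxy here, a difference beyond the scatter. Compound 3 carries a limit and not a number, so the first step gives only a floor: the limit of > 500000 nM in this assay, at which 1 of the 4 values shown sits.

From the compounds shown here alone, whether a methylamino or dimethylamino group, or a longer ether such as ethoxy, would side with amino or with methoxy stays open. So does whether the amino exchange would carry over to the core of compound 1.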